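The source may hold more compounds than are shown below. What is called first, only, known or untested is meant among the compounds shown, and "the series" means these compounds.

Among the measured compounds shown here, in an in vitro functional assay on cells for agonist activity at Bombesin receptor subtype-3 (Homo sapiens), read by luminescence and calcium flux (on this read-out lower numbers stand for an effect already at smaller amounts and higher numbers for an effect only at larger amounts of compound), compound 1 `O=C(O)c1ccccc1-c1ccc(CCc2ncc(Cc3ccccc3Cl)[nH]2)cc1` gives 292 nM, the second highest of the three numbers measured so far. Compound 2 `CC(C)(C)CCc1cnc(CCc2ccc(-c3ccccc3C(=O)O)cc2)[nH]1` gives 39 nM, and compound 3 `Cc1ccc(Cc2cnc(CCc3ccc(-c4ccccc4C(=O)O)cc3)[nH]2)cc1` gives 2660 nM. These three compounds differ only in the group on a saturated chain carbon bound to an aromatic carbon: a 7.5-fold lower number from compound 1 to compound 2 (0.87 log units; beyond the scatter), a 9.1-fold higher number from compound 1 to compound 3 (0.96 log units; beyond the scatter), and a 68-fold higher number from compound 2 to compound 3 (1.83 log units; beyond the scatter). Compound 4 `O=C(O)c1ccccc1-c1ccc(CCc2ncc(Cc3ccccc3)[nH]2)cc1` has not yet been measured; it differs from compound 1 by hydrogen in place of chloro on an aromatic carbon. For the measured compounds named here, no measured step removes a single substituent from the aryl; the closest comparisons are the two that exchange the whole 2-chlorophenyl, and both moved the number modestly. The change from compound 1 to compound 4 is smaller than either of those, so a smaller step is expected, leaning toward a higher number because a 9.1-fold higher number from compound 1 to compound 3 (0.96 log units; beyond the scatter) shows that a different aryl pattern gave a weaker effect, while compound 2 with its neopentyl stands apart. For compound 4 the step of a 2.4-fold higher number from compound 1 to compound 4 (0.38 log units; beyond the scatter) is expected. Compound 4 is therefore estimated at 700 nM, with a range from 250 nM to 2500 nM.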

Compound 4, half-maximal effective concentration: 205 nM
For compound 4 the middle estimate is 3.4-fold (0.53 log units) above the measured one, outside the stated range (below it).
By their numbers in this assay, from the lowest: compound 2; then compounds 4 and 1 (each within the scatter of the next); then compound 3.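

In this assay, hydrogen in place of chloro on the aromatic carbon ortho to a large group gives a 1.4-fold lower number from compound 1 to compound 4 (0.15 log units; within the scatter) and so leaves compound 1 and compound 4 indistinguishable, which shows that the chloro of the 2-chlorophenyl makes no readable difference at this place. Hydrogen in place of methyl is another matter, since it gives a 13-fold lower number from compound 3 to compound 4 (1.11 log units; beyond the scatter) and thus ties the high number of compound 3 to the methyl of its 4-methylphenyl and not to the aryl group as such. The plain benzyl also does not close the gap to the neopentyl chain, as a 5.3-fold higher number from compound 2 to compound 4 (0.72 log units; beyond the scatter) shows, and compound 2 keeps the lowest number of the four, beyond the scatter from each of the others.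

The compounds shown leave open whether a chloro in the place of that methyl would behave like the methyl, and whether a methoxy on the phenyl, or an amine or a longer chain in place of the neopentyl, would carry the number further in either direction. Nothing available here gives a reason for any of these differences.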